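A few compounds are considered here, and "the series" means these few. Any claim that something is new, unique, unknown or untested is made for them only; others in the source may bear on it.

In a physicochemical assay for solubility, in phosphate buffer, measured as kinetic solubility, at pH 7.4 (on this read-out higher numbers stand for higher solubility and lower numbers for lower solubility), compound 1 `Cc1oc(-c2ccccc2Cl)nc1CN1CCC(C(=O)NCCCN2C[C@H](C)C[C@H](C)C2)CC1` gives > 72 ug/mL, which is a limit of the assay and not a number. Compound 2 `Cc1ccccc1-c1nc(CN2CCC(C(=O)NCCCN3CCCC(C(C)C)C3)CC2)c(C)o1` gives > 71 ug/mL, also a limit. Compound 3 `Cc1ccccc1-c1nc(CN2CCC(C(=O)NCCCCN3C[C@H](C)C[C@H](C)C3)CC2)c(C)o1` gives > 71 ug/mL, again a limit.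

Compound 4 `Cc1oc(-c2c(Cl)cccc2C(F)(F)F)nc1CN1CCC(C(=O)NCCCN2C[C@H](C)C[C@H](C)C2)CC1` differs from compound 1 by trifluoromethyl in place of hydrogen on an aromatic carbon, so that 2-chlorophenyl becomes 2-chloro-6-(trifluoromethyl)phenyl.

Going by the values given here, the only measured step is a step that the two limits leave unreadable from compound 2 to compound 3. It lies on a saturated chain carbon, not on an aromatic carbon, so it gives no size for this change. With no readable step to draw on, none beyond the scatter is expected in this assay, and no direction can be assigned. This expectation rests on compound 1 and its limit of > 72 ug/mL. The expected size is a number no higher from compound 1 to compound 4 (the limit leaves the size open), an estimated step only. For compound 4 the estimated value is 72 ug/mL, with an expected range from 35 ug/mL to 90 ug/mL.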

Compound 4, solubility: 65.1 ug/mL
The estimate for compound 4 lay 1.1-fold (0.04 log units) above the measured number; measured number inside the range.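

Compound 4 is the only compound shown whose value in this assay is a number and not a limit of the assay, which makes trifluoromethyl in place of hydrogen on an aromatic carbon, turning 2-chlorophenyl into 2-chloro-6-(trifluoromethyl)phenyl, the one readable step in the series: an at least 1.1-fold lower number from compound 1 to compound 4 (0.04 log units; that floor lies within the scatter). That floor does not establish a real loss, so the data show only that this replacement at this place still leaves a measured value for the read-out. Compound 1 gives > 72 ug/mL, which is a limit, so the step has a floor but no known full size: the limit of > 72 ug/mL in this assay, at which 1 of the 4 values shown sits.

On these data alone, whether a nitrile, a methoxy group or an amine on the same aromatic carbon would give a number or a limit stays open. Also open, as far as these compounds go, is whether trifluoromethyl gives a step of similar size on compound 2 or compound 3, which carry no chloro group.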